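This account rests on a few compounds, and the source may have more. Where it says the series, first, only, none or still open, it means among the compounds named here.

Of the compounds shown here, three from one series have been measured in a functional assay on KG-1 cells (Homo sapiens) for antiproliferative activity; on this read-out higher numbers stand for an effect only at larger amounts of compound and lower numbers for an effect already at smaller amounts. Compound 1, `NC(=O)c1cc(Cl)c2c(Cl)c(C#CC3CCOCC3)n([C@H]3CCCNC3)c2n1`, gives 69 nM in this assay. Compound 2, `CC(C)(C#N)CC#Cc1c(Cl)c2c(Cl)cc(C(N)=O)nc2n1[C@H]1CCCNC1`, gives 113 nM. Compound 3, `CC(C)(O)C#Cc1c(Cl)c2c(Cl)cc(C(N)=O)nc2n1[C@H]1CCCNC1`, gives 302 nM, the highest of the three numbers; its nearest neighbour is compound 2, as a 2.7-fold higher number from compound 2 to compound 3 (0.43 log units; beyond the scatter) shows, and its furthest is compound 1, as a 4.4-fold higher number from compound 1 to compound 3 (0.64 log units; beyond the scatter) shows. Between compound 1 and compound 2 the difference is a 1.6-fold higher number from compound 1 to compound 2 (0.21 log units; within the scatter).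

Compound 4, `COCC(C)(C)C#Cc1c(Cl)c2c(Cl)cc(C(N)=O)nc2n1[C@H]1CCCNC1`, differs from compound 3 in one place: methoxymethyl in place of hydroxy on a saturated chain carbon bound to two saturated chain carbons and a triple-bonded carbon. The two steps that bear on this are those into compound 3, a 4.4-fold higher number from compound 1 to compound 3 (0.64 log units; beyond the scatter) and a 2.7-fold higher number from compound 2 to compound 3 (0.43 log units; beyond the scatter), both of which led from a group without a hydrogen-bond donor to the hydroxy group and both of which raised the number beyond the scatter. Since compound 4 again carries no donor at that carbon, a step back toward the numbers of compound 1 and compound 2 is expected, and the expected change is a 2.3-fold lower number from compound 3 to compound 4 (0.37 log units; beyond the scatter). Compound 4 is therefore estimated at 130 nM, with a range from 60 nM to 300 nM.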

Compound 4, half-maximal effective concentration: 219 nM
Estimate against measurement, compound 4: 1.7-fold (0.23 log units) below, within the range that was stated.
By their numbers in this assay, from the lowest: compounds 1, 2, 4 and 3 (each within the scatter of the next, the first and the last beyond it).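

Replacing the hydroxy group with methoxymethyl, which removes the hydrogen-bond donor at this carbon, produces no step beyond the scatter (a 1.4-fold lower number from compound 3 to compound 4 (0.14 log units; within the scatter)), so the donor's absence alone does not separate compound 4 from compound 3. Compound 4 also stays within the scatter of compound 2, which carries 2-cyano-2-methylpropyl on the triple-bonded carbon (a 1.9-fold higher number from compound 2 to compound 4 (0.29 log units; within the scatter)), whereas the oxan-4-yl of compound 1 remains clearly apart from the 1-(methoxymethyl)-1-methylethyl of compound 4 (a 3.2-fold higher number from compound 1 to compound 4 (0.50 log units; beyond the scatter)). Nothing available explains these differences.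

The compounds shown leave open whether the separation of compound 1 depends on its oxane ring or would also appear with a piperidine or cyclohexyl ring on the triple-bonded carbon. They also leave open how an amine or a carboxylic acid at this position would read out.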